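Replacing the side chain of compound 3

The source may hold more compounds than are shown below. What is called first, only, known or untested is meant among the compounds shown, and "the series" means these compounds.

In a functional assay on the whole organism (heart) with Rattus norvegicus as the target (a lower number here means that less compound is needed, a higher number that more compound is needed for the effect), compound 1 (`CC(=O)/C(=C\c1ccccc1)Oc1ccc(OCC(C)N(C)C)cc1`) gives 3 mg/kg, compound 2 (`CC(=O)/C(=C\c1ccccc1)Oc1ccccc1OCC(O)CNC(C)(C)C`) gives 1.9 mg/kg and compound 3 (`CC(=O)/C(=C\c1ccccc1)Oc1ccccc1OCCCNC(C)(C)C`) gives 1.5 mg/kg. Compound 3 therefore stands within the usual scatter of both others. Compound 4 (`CC(=O)/C(=C\c1ccccc1)Oc1ccccc1OCC(O)CN1CCN(C)CC1`) shares the core of compound 3 but has not yet been measured. The change is 1-hydroxy-2-(4-methylpiperazin-1-yl)ethyl in place of 2-((tert-butyl)amino)ethyl on a saturated chain carbon bound to an oxygen on an aromatic ring. Among the measured compounds shown here, only one measured step bears on it, a 1.3-fold lower number from compound 2 to compound 3 (0.10 log units; within the scatter), which concerns a hydroxy group on the chain, and compound 4 carries such a group too. For the measured compounds named here, no measured compound carries the 4-methylpiperazin-1-yl group, so a firm forecast is not possible. In this assay the expected step is small, a 1.7-fold higher number from compound 3 to compound 4 (0.22 log units; within the scatter), and stays within the scatter. For compound 4 the estimated value is 2.5 mg/kg, with an expected range from 0.8 mg/kg to 8 mg/kg.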

Compound 4, dose for half-maximal effect: 7.5 mg/kg
Compound 4: middle estimate off by 3.0-fold (0.48 log units), on the low side; low and high end bracket the measured number.
By their numbers in this assay, from the lowest: compounds 3, 2 and 1 (each within the scatter of the next); then compound 4.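

In this assay, swapping (tert-butyl)amino for 4-methylpiperazin-1-yl while the hydroxy group stays gives a 3.9-fold higher number from compound 2 to compound 4 (0.60 log units; beyond the scatter), so this end of the chain responds to change in a way the hydroxy step alone did not show. The full replacement of 2-((tert-butyl)amino)ethyl gives a 5.0-fold higher number from compound 3 to compound 4 (0.70 log units; beyond the scatter) and also lies beyond the scatter. Nothing shown accounts for this rise.

Going by these compounds, it remains open how the 4-methylpiperazin-1-yl group behaves on a chain without the hydroxy group. Other rings at this place, such as morpholine or piperidine, also remain untested here.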